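A few compounds are considered here, and "the series" means these few. Any claim that something is new, unique, unknown or untested is made for them only; others in the source may bear on it.

Compound 1, `O=C(C1CCC1)N1CCCC[C@@H]1c1nc(-c2cccc(F)c2)no1` — in an in vitro functional assay on HEK293-A cells for positive allosteric modulation of metabotropic glutamate receptor 5 (Homo sapiens), read by fluorescence and calcium flux, with a stated time of 140 s (on this read-out higher numbers stand for an effect only at larger amounts of compound and lower numbers for an effect already at smaller amounts), compound 1 gives 600 nM; 650 nM (2 entries).
Compound 2, `O=C(c1cccc(F)c1)N1CCCC[C@@H]1c1nc(-c2cccc(F)c2)no1` — in this assay compound 2 gives 460 nM.

For the measured compounds named here, compound 2 has only that single number in this assay, plus one further entry without a number; compound 1 has the repeated readings of the several entries of compound 1 in this assay, 600 nM; 650 nM (2 entries). Compound 3, `O=C(c1ccc(F)cc1)N1CCCC[C@@H]1c1nc(-c2cccc(F)c2)no1`, differs from compound 2 by 4-fluorophenyl in place of 3-fluorophenyl on a carbonyl carbon. Going by the values given here, with no measured pair showing such a change, the expected step of a 1.1-fold higher number from compound 2 to compound 3 (0.04 log units; within the scatter) is small, not beyond the usual scatter, in either direction. Compound 3 is therefore estimated at 500 nM, expected between 200 nM and 1500 nM.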

Compound 3, half-maximal effective concentration: 23000 nM
Beside the measured number, compound 3's estimate is 46-fold (1.66 log units) below it; the whole stated range lies below it.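

Swapping 3-fluorophenyl for 4-fluorophenyl on the carbonyl carbon keeps the same atoms yet gives a 50-fold higher number from compound 2 to compound 3 (1.70 log units; beyond the scatter) in this assay. At this position, then, the read-out depends sharply on how the fluorine is placed on the ring, not only on which atoms are present. Repeat readings agree far more closely than this step, as seen in: the several entries of compound 1 in this assay, 600 nM; 650 nM (2 entries)

The compounds shown do not tell why the number rises so steeply. They also leave open whether a plain phenyl or a 4-chlorophenyl group on the same carbonyl carbon would behave like 3-fluorophenyl or like 4-fluorophenyl.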